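Sulfonyl aryl isomer and cytotoxicity in liver cells

The source may hold more compounds than are shown below. What is called first, only, known or untested is meant among the compounds shown, and "the series" means these compounds.

Three compounds built on one shared core have been examined in an ADME assay on HepG2 2.2.15 cells (Homo sapiens) for cytotoxicity; on this read-out higher numbers stand for lower toxicity in this test and lower numbers for higher toxicity in this test. Compound 1 `CCCCC(CC)CNc1ncc(C(Oc2ccc3cc(Br)ccc3c2)c2ccc(Cl)cc2)s1` is recorded in this assay as "not toxic" (no number reported), with no number attached. Compound 2 `Clc1ccc(C(Oc2ccc3cc(Br)ccc3c2)c2cnc(NCC3CCOCC3)s2)cc1` likewise comes out as "not toxic" (no number reported). For compound 3 `Cc1ccc(C)c(S(=O)(=O)Nc2ncc(C(Oc3ccc4cc(Br)ccc4c3)c3ccc(Cl)cc3)s2)c1` the read-out is a limit of the assay, > 50000 nM, and not a measured number. That is the limit described as the limit of > 50000 nM in this assay, at which 1 of the 3 values shown sits. For the measured compounds named here, compound 3 thus stands at the edge of what the assay resolves, next to two entries that carry no number at all, so no step between measured compounds can be sized.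

Compound 4 `CCc1ccc(S(=O)(=O)Nc2ncc(C(Oc3ccc4cc(Br)ccc4c3)c3ccc(Cl)cc3)s2)cc1` differs from compound 3 in a single place: 4-ethylphenyl in place of 2,5-dimethylphenyl on a sulfonyl sulfur, the same atoms joined differently. Going by the values given here, no measured pair shows what such a rearrangement does in this assay. The step from the isomer is expected to be a number no higher from compound 3 to compound 4 (the limit leaves the size open), nothing beyond the scatter of repeated measurements. Compound 4 is accordingly estimated at 50000 nM, within a range from 25000 nM to 100000 nM, and will most probably again be reported only as a limit.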

Compound 4, half-maximal cytotoxic concentration: > 50000 nM
Compound 4: no number, only a limit (the forecaster's own chance of this, stated with the estimate: 80%); the middle value lies on the limit itself.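

Compound 3 and compound 4 both sit at a limit of this assay, so no step between them can be read: the limit of > 50000 nM in this assay, at which 2 of the 4 values shown sit.

The compounds shown leave open whether 4-ethylphenyl in place of 2,5-dimethylphenyl on a sulfonyl sulfur shifts the read-out of this assay at all.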